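The source may report more compounds than this note shows. Statements on the series, on what has been measured and on what is new or still open speak of the compounds shown alone.

Compound 1 `COc1ccccc1CNc1nc2c(N)ncnc2n1[C@@H]1O[C@H](CO)[C@@H](O)[C@H]1O` is one of three nucleoside analogues tested in an assay on COS-7 cells for inhibition of sodium/nucleoside cotransporter 2 (Homo sapiens), read by scintillation counting, in the presence of a further agent that is not named here; a higher number here means a weaker inhibitor, a lower number a stronger inhibitor. In this assay compound 1 gives > 100000 nM, which is a limit of the assay rather than a number. Compound 2 `Cc1ccccc1CNc1nc2c(N)ncnc2n1[C@@H]1O[C@H](CO)[C@@H](O)[C@H]1O` gives 65000 nM in this assay. Compound 3 `Nc1ncnc2c1ncn2[C@@H]1O[C@H](COC(=O)NCc2ccccc2)[C@@H](O)[C@H]1O` also gives only a limit, > 100000 nM, in this assay. Among the compounds with values here, the one step between two compounds that differ in a single place, methyl in place of methoxy on an aromatic carbon, is an at least 1.5-fold lower number from compound 1 to compound 2 (0.18 log units; that floor lies within the scatter). Two of the three values sit at the limit of > 100000 nM in this assay, at which 2 of the 3 values shown sit, so compound 1 stands among the weakest inhibitors that this set can show, with no number of its own.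

Compound 4 `Nc1ncnc2c1nc(NCc1cccc3ccccc13)n2[C@@H]1O[C@H](CO)[C@@H](O)[C@H]1O` differs from compound 1 by naphthalen-1-yl in place of 2-methoxyphenyl on a saturated chain carbon bound to a nitrogen on an aromatic ring. Within the data shown here, no measured step swaps one aromatic group for another of a different ring count, so the step from compound 1 to compound 2 is the only guide, and it barely reaches beyond the scatter floor. Compound 4 is therefore expected to land near the top of the measurable range, with a step estimated as an at least 1.6-fold lower number from compound 1 to compound 4 (0.22 log units; that floor lies within the scatter). The estimate for compound 4 in this assay is 60000 nM, within a range from 15000 nM to 200000 nM.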

Compound 4, half-maximal inhibitory concentration: 5700 nM
The estimate for compound 4 lay 11-fold (1.02 log units) above the measured number, outside the stated range (below it).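

In this assay, the place on a saturated chain carbon bound to a nitrogen on an aromatic ring proves able to move the number by a large margin, which the earlier swap of methoxy for methyl on a single ring, an at least 1.5-fold lower number from compound 1 to compound 2 (0.18 log units; that floor lies within the scatter), could not show. The clearest reading comes from putting naphthalen-1-yl in place of 2-methylphenyl, an 11-fold lower number from compound 2 to compound 4 (1.06 log units; beyond the scatter), since both ends of this step are real numbers and the entering group brings a second six-membered aromatic ring of carbon only. Putting naphthalen-1-yl in place of 2-methoxyphenyl gives an at least 17-fold lower number from compound 1 to compound 4 (1.24 log units; beyond the scatter), and this size is only a floor, as the value for compound 1 is a limit of the assay and not a number: the limit of > 100000 nM in this assay, at which 2 of the 4 values shown sit.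

The compounds shown cannot separate the effect of the second ring from that of the larger group as a whole, and a cyclohexylmethyl or biphenyl group at the same place would help to tell these apart. On these data alone, it also remains open how the number responds to naphthalen-2-yl, which would show whether the way the two rings are attached matters, or to a longer chain between the nitrogen and the ring.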